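A few compounds are considered here, and "the series" means these few. Any claim that something is new, unique, unknown or untested is made for them only; others in the source may bear on it.

Working notes on the series.

Three compounds have numbers in an assay on THP-1 cells for displacement of a labelled ligand from C-C chemokine receptor type 1 (Homo sapiens); on this read-out lower numbers stand for stronger inhibition and higher numbers for weaker inhibition. Compound 1 `Cc1ccc(CCC(=O)N[C@@H](C(=O)N2CCC(c3ccc(Cl)cc3)CC2)C(C)C)cc1` gives 105 nM in this assay, the lowest of the three. Compound 2 `CC(C)C(NS(=O)(=O)Cc1ccccc1)C(=O)N1CCC(c2ccc(Cl)cc2)CC1` gives 303 nM in this assay, and compound 3 `CC(C)C(NC(=O)c1ccccc1)C(=O)N1CCN(c2ccc(Cl)cc2)CC1` gives 525 nM in this assay; both of these gaps to compound 1 fall beyond the scatter, so compound 1 is the most potent of the three as measured.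

The next compound, compound 4 `Cc1ccccc1C(=O)N[C@@H](C(=O)N1CCC(c2ccc(Cl)cc2)CC1)C(C)C`, is not yet measured in this assay. It differs from compound 1 in one place: 2-methylphenyl in place of 2-(4-methylphenyl)ethyl on a carbonyl carbon. Within the data shown here, no step between measured compounds matches this change, so the expectation rests on what the three numbers show. Compound 3, which also carries an aromatic ring on the carbonyl carbon of the amide, gives 525 nM in this assay, and on that basis a shift toward weaker binding is expected. The expected step is a 2.5-fold higher number from compound 1 to compound 4 (0.39 log units; beyond the scatter), a loss of moderate size. Compound 4 is estimated at 260 nM in this assay, with a range from 80 nM to 850 nM.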

Compound 4, half-maximal inhibitory concentration: 32 nM
Beside the measured number, compound 4's estimate is 8.1-fold (0.91 log units) above it; the whole stated range lies above it.
By their numbers in this assay, from the lowest: compound 4; then compound 1; then compounds 2 and 3 (each within the scatter of the next).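

In this assay, 2-methylphenyl in place of 2-(4-methylphenyl)ethyl on a carbonyl carbon gives a 3.3-fold lower number from compound 1 to compound 4 (0.52 log units; beyond the scatter), so at this position the smaller group, with 7 heavy atoms against 9, gains binding rather than losing it. Each group holds one six-membered aromatic ring of carbon only, and neither brings a hydrogen-bond donor or acceptor, so the counted difference lies in carbon atoms alone. Among these compounds, nothing measured so far gives a reason for the gain.

This single step does not separate the loss of the ethyl chain from the different placement of the methyl group. Open too, as far as these compounds go, is whether plain phenyl, 2-chlorophenyl or a pyridine ring on this carbonyl carbon would keep the number seen for compound 4 32 nM or lose it.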